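Swapping dimethoxyphenyl for tert-butylphenyl on a shared core

A few compounds are considered here, and "the series" means these few. Any claim that something is new, unique, unknown or untested is made for them only; others in the source may bear on it.

Measured in a functional assay on HepG2 cells (Homo sapiens) for antiproliferative activity, read by MTT assay, with a stated time of 48 h (a higher number here means a weaker inhibitor, a lower number a stronger inhibitor), as follows
Compound 1 `COc1ccc(-c2ccc3c(c2)C(=O)C(=O)N3Cc2ccc3ccccc3c2)cc1` gives 380 nM in this read-out
Compound 2 `COc1ccc(CN2C(=O)C(=O)c3c(-c4ccc(OC)cc4)cccc32)cc1` gives > 10000 nM as a limit of the assay
Compound 3 `COc1ccc(CN2C(=O)C(=O)c3cc(-c4cc(OC)cc(OC)c4)ccc32)cc1` gives 1200 nM in this read-out

Among the actual numbers in this assay compound 3 stands higher, at 1200 nM in that read-out, and compound 1 stands lower, at 380 nM in the same read-out, a gap beyond the usual scatter. Compound 2 is recorded only as a limit (> 10000 nM) of the assay.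

Compound 4 `COc1ccc(CN2C(=O)C(=O)c3cc(-c4ccc(C(C)(C)C)cc4)ccc32)cc1` has not yet been measured. It carries 4-(tert-butyl)phenyl in place of 3,5-dimethoxyphenyl on an aromatic carbon of a six-membered aromatic ring of carbon only, part of a fused or bridged system of two rings. Among the measured compounds shown here, no measured pair shows this exchange on its own, so the expectation rests on compound 3 at 1200 nM as its starting point. In this assay no change beyond the usual scatter is expected, and any drift is expected toward a slightly higher number. The estimated step (a 1.3-fold higher number from compound 3 to compound 4 (0.10 log units; within the scatter)) stays within that scatter. For compound 4 the expected value is 1500 nM with an estimated range from 500 nM to 5000 nM as its outer end.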

Compound 4, half-maximal inhibitory concentration: 4580 nM
The estimate for compound 4 lay 3.1-fold (0.48 log units) below the measured number, within the range that was stated.
By their numbers in this assay, from the lowest: compound 1; then compound 3; then compound 4. At a limit, above all of these: compound 2.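

In this assay, among the compounds shown here, putting 4-(tert-butyl)phenyl in place of 3,5-dimethoxyphenyl gives a 3.8-fold higher number from compound 3 to compound 4 (0.58 log units; beyond the scatter), so this is the first direct evidence that the aryl group at this position, meta to one fused ring and para to the other, can change the read-out on the shared core. The size of the group as counted does not separate the pair, since both groups have 10 heavy atoms and one six-membered aromatic ring of carbon only, whereas the leaving group has 2 hydrogen-bond acceptors and the entering group has 0. Nothing measured here explains the step, and this single exchange establishes no wider trend.

The exchange removes both methoxy groups and adds the tert-butyl group at once, so the compounds shown do not separate the contribution of either change. From the compounds shown here alone, it also remains open how a plain phenyl, or a phenyl carrying an amine or a carboxylic acid, would read at this position on the same core.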